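Swapping 2-methoxyphenyl for 2-bromophenyl on the carbonyl

The source may hold more compounds than are shown below. What is called first, only, known or untested is meant among the compounds shown, and "the series" means these compounds.

In a functional assay on MCF7 cells (Homo sapiens) for inhibition, read by MTT assay, with a stated time of 24 h (a lower number here means a stronger inhibitor of growth, a higher number a weaker inhibitor of growth), compound 1 `COc1ccccc1C(=O)n1c(-c2cn(C)c3ccccc23)nc2ccccc21` gives 32100 nM and compound 2 `COc1ccc2c(c1)c(-c1nc3ccccc3n1C(=O)c1ccccc1OC)cn2C` gives 23900 nM with the two numbers within the scatter of each other. Compound 2 therefore cannot be separated from compound 1 on the numbers available. Going by the values given here, the only measured step is a 1.3-fold lower number from compound 1 to compound 2 (0.13 log units; within the scatter) for methoxy in place of hydrogen on an aromatic carbon, and it lies within the scatter while leaving the 2-methoxyphenyl unchanged.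

Compound 3 `COc1ccc2c(c1)c(-c1nc3ccccc3n1C(=O)c1ccccc1Br)cn2C` carries bromo in place of methoxy on an aromatic carbon, ortho to a large group, turning (2-methoxyphenyl)carbonyl into (2-bromophenyl)carbonyl (bromo in place of methoxy on an aromatic carbon). Among the compounds with values here, no measured step replaces this methoxy, so the data give no direct size for the change, and the one step available offers only weak guidance. No step beyond the scatter is expected in this assay on this evidence. The expected result is a 1.1-fold lower number from compound 2 to compound 3 (0.04 log units; within the scatter) as an estimated step within the scatter. The estimate starts from compound 2 at 23900 nM as its anchor. Compound 3 is estimated at 22000 nM with an expected range from 9000 nM to 55000 nM for this measurement.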

Compound 3, concentration for 50% growth inhibition: 55800 nM
Beside the measured number, compound 3's estimate is 2.5-fold (0.40 log units) below it; measured number outside the range, above it.
By their numbers in this assay, from the lowest: compounds 2, 1 and 3 (each within the scatter of the next, the first and the last beyond it).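

Going by these compounds alone, the ring carrying the carbonyl gives the first step that lies beyond the scatter: in this assay, bromo in place of methoxy on an aromatic carbon, ortho to a large group, gives a 2.3-fold higher number from compound 2 to compound 3 (0.37 log units; beyond the scatter), a modest loss as a growth inhibitor. Within the data shown here, the only earlier step, a 1.3-fold lower number from compound 1 to compound 2 (0.13 log units; within the scatter), lies within the scatter and left the 2-methoxyphenyl unchanged, so it gave no reading of this position; the number in this assay now proves sensitive to the group held there, and 2-methoxyphenyl reads better than 2-bromophenyl on the core of compound 2. No measurement shown here accounts for the difference between the two groups.

Whether an amine or a carboxylic acid at this same place would bring the number back towards that of compound 2 or raise it further remains open, as only methoxy and bromo are shown there. Also open, from the compounds shown here alone, is whether the step from 2-methoxyphenyl to 2-bromophenyl keeps its size on the core of compound 1, which lacks the methoxy of compound 2 on the shared core.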